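This account rests on a few compounds, and the source may have more. Where it says the series, first, only, none or still open, it means among the compounds named here.

Among the compounds with values here, compound 2 `COc1ccc(NC(=O)Nc2nnc(Sc3ncnc4scc(-c5ccncc5)c34)s2)cc1` gives 16900 nM in a functional assay on HUVEC cells (Homo sapiens) for antiproliferative activity, read by MTT assay, with a stated time of 48 h (on this read-out lower numbers stand for stronger inhibition and higher numbers for weaker inhibition), one of only two numbers recorded; the other belongs to compound 1 `O=C(Nc1cccc(C(F)(F)F)c1)Nc1nnc(Sc2ncnc3scc(-c4ccncc4)c23)s1`, which gives 22400 nM, and the gap between the two lies within the scatter, so neither compound stands apart. Within the data shown here, the single measured step, a 1.3-fold lower number from compound 1 to compound 2 (0.12 log units; within the scatter), changed the group on the same aromatic ring and did not move the read-out beyond the scatter. Compound 3 `Cc1ccc(NC(=O)Nc2nnc(Sc3ncnc4scc(-c5ccncc5)c34)s2)cc1` differs from compound 2 by methyl in place of methoxy on an aromatic carbon. Among the measured compounds shown here, because the only related step of a 1.3-fold lower number from compound 1 to compound 2 (0.12 log units; within the scatter) stayed within the scatter, no shift beyond the scatter is expected in this assay. Compound 3 is therefore estimated at 17000 nM (range 8000 nM to 36000 nM), an expected step of a 1.0-fold higher number from compound 2 to compound 3 (0.00 log units; within the scatter).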

Compound 3, half-maximal inhibitory concentration: 19300 nM
The estimate for compound 3 lay 1.1-fold (0.06 log units) below the measured number, and the stated range covers the measured number.
By their numbers in this assay, from the lowest: compounds 2, 3 and 1 (each within the scatter of the next).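

In this assay methyl in place of methoxy on an aromatic carbon para to a large group gives a 1.1-fold higher number from compound 2 to compound 3 (0.06 log units; within the scatter) and so the methoxy oxygen can be lost with no shift beyond the scatter. The second step, with 4-methylphenyl in place of 3-(trifluoromethyl)phenyl, gives a 1.2-fold lower number from compound 1 to compound 3 (0.06 log units; within the scatter) and also stays within the scatter, so these three aryl groups cannot be told apart here. No evidence bears on why these numbers stay so close. Still open, going by these compounds, is whether an amine or a carboxylic acid at this para position would move the number beyond the scatter.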